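This account rests on a few compounds, and the source may have more. Where it says the series, first, only, none or still open, it means among the compounds named here.

Measured in a functional assay on NCI-H460 cells (Homo sapiens); on this read-out higher numbers stand for an effect only at larger amounts of compound and lower numbers for an effect already at smaller amounts:
- compound 1 `COc1cc(C2OC(c3ccc(N(C)C)cc3)=NN2C(=O)COC(C)=O)cc(OC)c1OC`: 0.072 uM
- compound 2 `COc1cc(C2OC(c3ccc(N(C)C)cc3)=NN2C(=O)CN=[N+]=[N-])cc(OC)c1OC`: 0.53 uM
- compound 3 `COc1cc(C2OC(c3ccc(N(C)C)cc3)=NN2C(=O)CN)cc(OC)c1OC`: 0.66 uM

In this assay, compound 3 stands at 0.66 uM. The data show a 9.2-fold higher number from compound 1 to compound 3 (0.96 log units; beyond the scatter), while a 1.2-fold higher number from compound 2 to compound 3 (0.10 log units; within the scatter) shows no separation between those two compounds.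

Compound 4 `COc1cc(C2OC(c3ccc(N(C)C)cc3)=NN2C(=O)CNC=O)cc(OC)c1OC` is reached from compound 3 by formyl in place of hydrogen on an amine nitrogen. Among the measured compounds shown here, no measured step makes this exact change, so the evidence is indirect. The nearest guide is compound 1, whose acetoxy group, like the formylamino group of compound 4, holds a carbonyl. The steps away from it are modest: a 7.4-fold higher number from compound 1 to compound 2 (0.87 log units; beyond the scatter), and the step to compound 3 given above. A partial move back towards compound 1 therefore seems likely, though it remains uncertain, and the expected change is a 2.6-fold lower number from compound 3 to compound 4 (0.42 log units; beyond the scatter). Compound 4 is estimated at 0.25 uM, with an expected range from 0.06 uM to 0.9 uM.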

Compound 4, concentration for half-maximal effect: 0.04 uM
Compound 4: middle estimate off by 6.3-fold (0.80 log units), on the high side; the measured number lies below the stated range.
By their numbers in this assay, from the lowest: compounds 4 and 1 (each within the scatter of the next); then compounds 2 and 3 (each within the scatter of the next).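

In this assay, formyl in place of hydrogen on the amine nitrogen is a large change (a 17-fold lower number from compound 3 to compound 4 (1.22 log units; beyond the scatter)), so what this nitrogen carries matters more than the earlier amino and azido compounds suggested, as those two showed no separation (a 1.2-fold higher number from compound 2 to compound 3 (0.10 log units; within the scatter)). The formylamino group also stands clearly apart from azido (a 13-fold lower number from compound 2 to compound 4 (1.12 log units; beyond the scatter)). Against acetoxy it shows no separation (a 1.8-fold lower number from compound 1 to compound 4 (0.26 log units; within the scatter)), so among these compounds the two groups holding a carbonyl, in compound 1 and compound 4, sit together at the low end of the numbers, with compound 2 and compound 3 at the high end.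

On these data alone, whether an acetylamino group, a longer acyl chain or a methylamino group on this nitrogen would sit with compound 4 or with compound 3 stays open. Nothing measured here accounts for the size of the step.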